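Anilino for Aryloxy Linker Change in Sulfonylurea Antagonists

This account rests on a few compounds, and the source may have more. Where it says the series, first, only, none or still open, it means among the compounds named here.

Two sulfonylureas have been measured in a functional assay on HEK293 cells for antagonist activity at thromboxane A2 receptor (Homo sapiens), read by fluorescence and calcium flux; on this read-out lower numbers stand for stronger inhibition and higher numbers for weaker inhibition. Compound 1 `Cc1cccc(Oc2ccc(C#N)cc2S(=O)(=O)NC(=O)NC(C)(C)C)c1` gives 1050 nM. Compound 2 `CCCCCNC(=O)NS(=O)(=O)c1cc(C#N)ccc1Oc1cccc(C)c1` gives 1330 nM, which is the higher of the two numbers; the step of a 1.3-fold higher number from compound 1 to compound 2 (0.10 log units; within the scatter) lies within the scatter, so the two compounds cannot be ordered. Compound 3 `CCCCCNC(=O)NS(=O)(=O)c1cc(C#N)ccc1Nc1ccc(F)cc1` has not yet been measured. It differs from compound 2 by (4-fluorophenyl)amino in place of 3-methylphenoxy on an aromatic carbon. Going by the values given here, none of the measured steps touches this part of the shared core: the only step, from tert-butyl to pentyl on the urea nitrogen, concerns a different position and was within the scatter. There is therefore no measured basis for a direction, and compound 3 is expected to land near compound 2, with a wide range, as a step of a 1.0-fold lower number from compound 2 to compound 3 (0.01 log units; within the scatter). The estimate for compound 3 in this assay is 1300 nM, between 300 nM and 6000 nM.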

Compound 3, half-maximal inhibitory concentration: 6780 nM
Estimate against measurement, compound 3: 5.2-fold (0.72 log units) below, outside the stated range (above it).
By their numbers in this assay, from the lowest: compounds 1 and 2 (each within the scatter of the next); then compound 3.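

In this assay, going by these compounds alone, this aromatic carbon, para to a cyano group and ortho to a large group, is the first place where a change gives a step beyond the scatter: (4-fluorophenyl)amino in place of 3-methylphenoxy gives a 5.1-fold higher number from compound 2 to compound 3 (0.71 log units; beyond the scatter) in this series. The change from tert-butyl to pentyl on the amide-type nitrogen, by contrast, stayed within the scatter. The entering group brings a hydrogen-bond donor that 3-methylphenoxy lacks and also differs in its ring substituent, and nothing available accounts for the step.

The compounds shown leave open whether the linking atom or the ring substituent carries the step, a question that 3-methylanilino or 4-fluorophenoxy at this position would separate. From the compounds shown here alone, it also remains open how a chlorine in place of the fluorine, or a plain amine here, would read.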